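The source may hold more compounds than are shown below. What is called first, only, known or untested is meant among the compounds shown, and "the series" means these compounds.

Two compounds sharing one core were tested in a functional assay on KYSE-410 cells (Homo sapiens) for antiproliferative activity, read by MTT assay, with a stated time of 72 h; on this read-out higher numbers stand for weaker inhibition and lower numbers for stronger inhibition. Compound 1 `COc1ccc2c(C(=O)Nc3cc(F)cc(F)c3)cc(=O)[nH]c2n1` reached only a limit of the assay, > 20000 nM, in this assay. Compound 2 `O=C(Nc1cccc(F)c1)c1cc(=O)[nH]c2cc(-c3ccccc3)ccc12` likewise reached only a limit, > 20000 nM. Going by the values given here, both values sit at the same limit (the limit of > 20000 nM in this assay, at which 2 of the 2 values shown sit), so no step between them can be sized, and compound 2 stands at that limit with nothing below it. Compound 3 `Nc1ccc(-c2ccc3c(C(=O)Nc4cccc(F)c4)cc(=O)[nH]c3c2)cc1` differs from compound 2 by amino in place of hydrogen on an aromatic carbon. Among the compounds with values here, no measured step of this kind exists, so the expected change in this assay is an at least 1.3-fold lower number from compound 2 to compound 3 (0.12 log units; that floor lies within the scatter), with no clear direction. Compound 3 is estimated at 15000 nM, within 3000 nM to 50000 nM.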

Compound 3, half-maximal inhibitory concentration: > 20000 nM
Compound 3: only a limit was reported; the forecaster's own chance of this, stated with the estimate: 60%; middle value at least 1.3-fold (0.12 log units) away from the limit.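

Going by these compounds alone, compound 2 and compound 3 both stop at the same limit of the assay, so no step between them can be read: the limit of > 20000 nM in this assay, at which 3 of the 3 values shown sit. The compounds shown leave open what amino in place of hydrogen does in this assay, and which change to the shared core would give a measurable value.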